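The source may report more compounds than this note shows. Statements on the series, on what has been measured and on what is new or still open speak of the compounds shown alone.

Working notes on the series.

Compound 1 `O=c1nc2ccccn2cc1Cc1ccc(F)cc1C(F)(F)F` is the measured parent of the first pair; in a functional assay on HeLa cells (Homo sapiens) for cytotoxicity, read by MTT assay, with a stated time of 24 h (on this read-out lower numbers stand for stronger inhibition and higher numbers for weaker inhibition), compound 1 gives 88000 nM. Compound 3 `O=c1nc2ccc(Cl)cn2cc1Cc1ccc(F)cc1C(F)(F)F` carries the change (chloro in place of hydrogen on an aromatic carbon). In this assay compound 3 gives > 1000000 nM, which is a limit of the assay and not a number. Between the two stands an at least 11-fold higher number from compound 1 to compound 3 (1.05 log units; beyond the scatter), a step whose lower bound follows from the limit of > 1000000 nM in this assay, at which 2 of the 3 values shown sit.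

Compound 2 `CC1(C)OC2O[C@@H](Cc3cn4ccccc4nc3=O)C(OCc3ccccc3)C2O1` has a different core; the difference between the two cores is not broken down here. In this assay compound 2 gives > 1000000 nM, which is a limit of the assay and not a number.

Compound 4 `CC1(C)OC2O[C@@H](Cc3cn4cc(Cl)ccc4nc3=O)C(OCc3ccccc3)C2O1` is not yet measured. It differs from compound 2 by chloro in place of hydrogen on an aromatic carbon. The place of the change is the same in words as for the first pair, so the change is taken as the same one, made for the second time among the compounds shown.

For compound 4 the expectation rests on two points: compound 2 already sits at the limit of > 1000000 nM in this assay, at which 2 of the 3 values shown sit, and the same change gave an at least 11-fold higher number from compound 1 to compound 3 (1.05 log units; beyond the scatter), a loss. The expected outcome for compound 4 is therefore a value at or beyond the limit, expressed as a step that the limit leaves unreadable from compound 2 to compound 4. The estimate for compound 4 in this assay is 2000000 nM, expected to lie between 1000000 nM and 10000000 nM, most likely reported only as a limit.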

Compound 4, half-maximal inhibitory concentration: > 1000000 nM
Compound 4: a limit, no number; the forecaster's own chance of this, stated with the estimate: 90%; the middle value lies beyond the limit too.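

Compound 2 and compound 4 both stand as limits of the assay and not as numbers in this assay, so no step can be read between them: the limit of > 1000000 nM in this assay, at which 3 of the 4 values shown sit.

The compounds shown leave open whether chloro in place of hydrogen on an aromatic carbon changes the read-out at all on the core of compound 2, as it did on the core of compound 1.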